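The source may report more compounds than this note shows. Statements on the series, on what has been measured and on what is new or still open speak of the compounds shown alone.

Measured compounds:
compound 1, `Cc1ccc(NC(=O)c2cccc(C(F)(F)F)c2)cc1C#Cc1nn(C[C@H](C)CO)c2ncnc(N)c12`: 10 nM
compound 2, `Cc1ccc(NC(=O)c2cnc(C(C)(C)C)s2)cc1C#Cc1nn(C[C@@H](C)CO)c2ncnc(N)c12`: 73 nM
compound 3, `Cc1ccc(NC(=O)c2ccc(C)c(C(F)(F)F)c2)cc1C#Cc1nn(C[C@@H](C)CO)c2ncnc(N)c12`: 123 nM

In a functional assay on MDA-MB-435 cells (Homo sapiens) for antiproliferative activity, read by MTT assay, with a stated time of 72 h (on this read-out higher numbers stand for weaker inhibition and lower numbers for stronger inhibition), compound 3 gives the highest number of the three. Compound 2 sits nearest, and the step of a 1.7-fold higher number from compound 2 to compound 3 (0.23 log units; within the scatter) lies within the scatter. Compound 1 shows a far lower number, but it differs from compound 3 both in the aryl group on the carbonyl carbon and in the configuration at the chain carbon, so its value cannot be pinned to either change. Compound 4, `Cc1ccc(NC(=O)c2ccc(C)c(C(F)(F)F)c2)cc1C#Cc1nn(C[C@H](C)CO)c2ncnc(N)c12`, is not yet measured; the change is the two compounds have the same atoms and bonds and differ only in configuration as drawn: 1 of 1 stereo elements differ; a stereocentre at a saturated chain carbon is drawn R in compound 3 and S in compound 4. Among the measured compounds shown here, no measured step isolates this change, so the data offer no direct guide. Compound 4 is drawn with the same configuration at the chain carbon as compound 1, and compound 1 gives 10 nM, which leaves a lower number possible. Compound 4 is estimated at 60 nM, with a range from 15 nM to 250 nM. The expected step is a 2.1-fold lower number from compound 3 to compound 4 (0.31 log units; beyond the scatter), held with wide uncertainty.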

Compound 4, half-maximal inhibitory concentration: 61 nM
Compound 4: middle estimate off by 1.0-fold (0.01 log units), on the low side; the range from low to high includes it.
By their numbers in this assay, from the lowest: compound 1; then compounds 4, 2 and 3 (each within the scatter of the next).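

In this assay the switch at the chain carbon from R to S gives a 2.0-fold lower number from compound 3 to compound 4 (0.30 log units; within the scatter) and so stays inside the scatter. Any gap in this pair can come only from that carbon: the fact that compounds 3 and 4 differ only in the configuration as drawn. Among the compounds shown here, with the configuration matched, the single change of methyl in place of hydrogen on an aromatic carbon gives a 6.1-fold higher number from compound 1 to compound 4 (0.79 log units; beyond the scatter) and this step lies beyond the scatter, which separates the two changes that compound 1 and compound 3 carry together. Still open, as far as these compounds go, is whether a methoxy group or a chlorine atom on that aromatic carbon would give a step like the one for methyl.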